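The source may report more compounds than this note shows. Statements on the series, on what has been measured and on what is new or still open speak of the compounds shown alone.

In a functional assay on HOS cells (Homo sapiens) for inhibition, with a stated time of 72 h (on this read-out lower numbers stand for stronger inhibition and higher numbers for weaker inhibition), compound 1 (`NC1CCC(Nc2nc(NCc3ccc(-c4ccccc4)nc3)c3ncn(C4CCCC4)c3n2)CC1`) gives 206 nM and compound 2 (`NC1CCC(Nc2nc(NCc3cc(Cl)ccc3O)c3ncn(C4CCCC4)c3n2)CC1`) gives 490 nM as the higher of the two numbers. For the measured compounds named here, the only measured step (a 2.4-fold higher number from compound 1 to compound 2 (0.38 log units; beyond the scatter)) is modest and falls at the same place as the next change. Compound 3 (`Nc1ccccc1CNc1nc(NC2CCC(N)CC2)nc2c1ncn2C1CCCC1`) is not yet measured and carries 2-aminophenyl in place of 5-chloro-2-hydroxyphenyl on a saturated chain carbon bound to a nitrogen on an aromatic ring. Going by the values given here, no measured step covers this exact exchange, so that single modest step gives only a rough scale. A shift no larger than that step is expected, most likely a slightly lower number that stays within the scatter (a 1.2-fold lower number from compound 2 to compound 3 (0.09 log units; within the scatter) as the estimated step in this assay for this pair). For compound 3 the estimated value is 400 nM with an expected range from 130 nM to 1200 nM in these notes.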

Compound 3, half-maximal inhibitory concentration: 2030 nM
The estimate for compound 3 lay 5.1-fold (0.71 log units) below the measured number; the measured number lies above the stated range.
By their numbers in this assay, from the lowest: compound 1; then compound 2; then compound 3.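

In this assay, this position on a saturated chain carbon bound to a nitrogen on an aromatic ring responds clearly to an exchange that leaves the counts of hydrogen-bond donors and acceptors unchanged: 2-aminophenyl in place of 5-chloro-2-hydroxyphenyl gives a 4.1-fold higher number from compound 2 to compound 3 (0.62 log units; beyond the scatter). Set against the 6-phenylpyridin-3-yl group, 2-aminophenyl gives a 9.9-fold higher number from compound 1 to compound 3 (0.99 log units; beyond the scatter), which places compound 1 lowest and compound 3 highest of the three. No measurement available here accounts for these steps.

As far as these compounds go, the exchange removes the chlorine and replaces the hydroxyl with an amine in one move, so the share of each in the step stays open. A plain 2-hydroxyphenyl group or a 5-chloro-2-aminophenyl group at this place would separate the two contributions.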